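The compounds below may be only part of what the source reports. "The series", "measured", "known", "first", "only" and "open" are said of these compounds alone.

In an assay on isolated protein for binding affinity to leukotriene B4 receptor (Homo sapiens) (a lower number here means a stronger inhibitor, a higher number a weaker inhibitor), compound 2 `CCc1cc(-c2ccc(F)cc2)c(O)cc1OCCCOc1cccc(OC)c1CCC(=O)O` gives 8.3 nM, the highest of the three numbers recorded here. Compound 1 `CCc1cc(-c2ccc(F)cc2)c(O)cc1OCCCOc1cccc(CCCCC(=O)N(C)C)c1CCC(=O)O` gives 3.1 nM and compound 3 `CCCc1c(OCCCOc2cc(O)c(-c3ccc(F)cc3)cc2CC)ccc2c1OC(C(=O)O)CC2` gives 3.8 nM. For the measured compounds named here, the one step that changes a single position, a 2.7-fold higher number from compound 1 to compound 2 (0.43 log units; beyond the scatter), shows that exchanging the group on this aromatic carbon shifts this assay only modestly. Compound 4 `CCc1cc(-c2ccc(F)cc2)c(O)cc1OCCCOc1ccccc1CCC(=O)O` differs from compound 2 by hydrogen in place of methoxy on an aromatic carbon, ortho to a 2-carboxyethyl group and meta to a large group. Going by the values given here, no measured step removes a group at this carbon outright, so the step from compound 1 to compound 2 is the only guide, and it was modest; the removal of a methoxy is a smaller change than that exchange. Compound 4 is therefore expected to give a number close to that of compound 2, if anything slightly higher. The estimated step, a 1.4-fold higher number from compound 2 to compound 4 (0.16 log units; within the scatter), is expected to stay within the scatter. The estimate for compound 4 is 12 nM, with a range from 5 nM to 30 nM.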

Compound 4, inhibition constant: 8 nM
The estimate for compound 4 lay 1.5-fold (0.18 log units) above the measured number, and the stated range covers the measured number.
By their numbers in this assay, from the lowest: compounds 1 and 3 (each within the scatter of the next); then compounds 4 and 2 (each within the scatter of the next).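

In this assay, taking the methoxy off this aromatic carbon, ortho to a 2-carboxyethyl group, leaves the result within the scatter (a 1.0-fold lower number from compound 2 to compound 4 (0.02 log units; within the scatter)), so these compounds do not tell hydrogen and methoxy apart at this place. This also gives the 4-(dimethylcarbamoyl)butyl group of compound 1 a comparison with hydrogen (a 2.6-fold higher number from compound 1 to compound 4 (0.41 log units; beyond the scatter)), and among the three groups at this carbon, only that chain goes with a lower number. No data shown here account for this difference.

The compounds shown leave open whether the lower number of compound 1 goes with the length of the chain or with its dimethylcarbamoyl end; a plain butyl chain or a chain ending in a carboxylic acid would separate the two. Also open, as far as these compounds go, is how a small amine at this carbon would compare with hydrogen and methoxy.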